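Changing the aryl group at the chain end

A few compounds are considered here, and "the series" means these few. Any claim that something is new, unique, unknown or untested is made for them only; others in the source may bear on it.

Of the compounds shown here, three sharing one core have been tested in a functional assay on RKE cells for antagonist activity at Vasoactive intestinal polypeptide receptor 1 (Rattus norvegicus), read by HTRF and cAMP accumulation, with stated times of 10 min and 30 min; a lower number here means a stronger inhibitor, a higher number a weaker inhibitor. Compound 1 `CCC(=O)Nc1sc2c(c1C#N)CCCC2` carries hydrogen on a saturated chain carbon, two bonds along the chain from a carbonyl carbon; in this assay compound 1 gives 12000 nM. Compound 2 `Cc1ccccc1CCC(=O)Nc1sc2c(c1C#N)CCCC2` carries 2-methylphenyl at that place, and compound 2 gives 11000 nM. Compound 3 `COc1cccc(CCC(=O)Nc2sc3c(c2C#N)CCCC3)c1` carries 3-methoxyphenyl there, and compound 3 gives 610 nM, the lowest of the three numbers. The step of a 1.1-fold lower number from compound 1 to compound 2 (0.04 log units; within the scatter) lies within the scatter, whereas a 20-fold lower number from compound 1 to compound 3 (1.29 log units; beyond the scatter) and an 18-fold lower number from compound 2 to compound 3 (1.26 log units; beyond the scatter) are both large. Compound 4 `N#Cc1c(NC(=O)CCc2ccc(Cl)cc2)sc2c1CCCC2` differs from compound 3 by 4-chlorophenyl in place of 3-methoxyphenyl on a saturated chain carbon, two bonds along the chain from a carbonyl carbon. Because the steps of a 20-fold lower number from compound 1 to compound 3 (1.29 log units; beyond the scatter) and an 18-fold lower number from compound 2 to compound 3 (1.26 log units; beyond the scatter) were large while 2-methylphenyl gave nothing over hydrogen, the identity of the aryl group clearly matters, yet 4-chlorophenyl has no precedent among these compounds. Compound 4 is therefore expected to fall between the extremes, with the step of a 4.9-fold higher number from compound 3 to compound 4 (0.69 log units; beyond the scatter) as the estimate. Compound 4 is estimated at 3000 nM, ranging from 600 nM to 12000 nM.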

Compound 4, half-maximal inhibitory concentration: 1200 nM
The estimate for compound 4 lay 2.5-fold (0.40 log units) above the measured number, and the stated range covers the measured number.
By their numbers in this assay, from the lowest: compounds 3 and 4 (each within the scatter of the next); then compounds 2 and 1 (each within the scatter of the next).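

In this assay, going by these compounds alone, 4-chlorophenyl on this saturated chain carbon improves on hydrogen (a 10-fold lower number from compound 1 to compound 4 (1.00 log units; beyond the scatter)) and on 2-methylphenyl (a 9.2-fold lower number from compound 2 to compound 4 (0.96 log units; beyond the scatter)), so compound 3 is no longer the only aryl compound with a much lower number, while compound 2 remains the aryl compound that shows no gain over hydrogen. The step of a 2.0-fold higher number from compound 3 to compound 4 (0.29 log units; within the scatter) does not separate 4-chlorophenyl from 3-methoxyphenyl, even though the hydrogen-bond acceptor counted in 3-methoxyphenyl is absent from 4-chlorophenyl. Nothing available here explains these differences.

The compounds shown do not tell whether the substituent's identity or its place on the ring separates compound 2 from compounds 3 and 4, as both change together. As far as these compounds go, how unsubstituted phenyl, a phenyl carrying a carboxylic acid or an amine, or a longer chain to the ring would compare also remains open.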